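Piperidinyl acrylamide variant of a quinazoline antiproliferative series

This account rests on a few compounds, and the source may have more. Where it says the series, first, only, none or still open, it means among the compounds named here.

Measured compounds:
compound 1 `CCC/C=C/C(=O)Nc1cc2c(N3CCc4ccccc43)ncnc2cc1OC` – 3160 nM
compound 2 `CCC/C=C/C(=O)Nc1cc2c(N3CCc4ccccc43)ncnc2cc1O[C@@H]1CCOC1` – 4550 nM

Compound 1 `CCC/C=C/C(=O)Nc1cc2c(N3CCc4ccccc43)ncnc2cc1OC` gives the lowest of the two numbers in a functional assay on MCF7 cells (Homo sapiens) for antiproliferative activity, read by MTT assay, with a stated time of 72 h; on this read-out higher numbers stand for weaker inhibition and lower numbers for stronger inhibition; its nearest neighbour, compound 2 `CCC/C=C/C(=O)Nc1cc2c(N3CCc4ccccc43)ncnc2cc1O[C@@H]1CCOC1`, sits within the scatter of it, as the step of a 1.4-fold higher number from compound 1 to compound 2 (0.16 log units; within the scatter) shows, that step being oxolan-3-yl in place of methyl on an oxygen on an aromatic ring. Compound 3 `COc1cc2ncnc(N3CCc4ccccc43)c2cc1NC(=O)/C=C/CN1CCCCC1` is not yet measured. It differs from compound 1 by piperidin-1-yl in place of ethyl on a saturated chain carbon bound to a double-bonded chain carbon. Among the compounds with values here, the only measured step concerns the ether on the aromatic ring and does not bear on the chain carrying the amide; no measured pair informs the change to compound 3. The estimate therefore rests on compound 1 alone, and a step of a 1.4-fold lower number from compound 1 to compound 3 (0.16 log units; within the scatter) is expected, towards a somewhat lower number. Compound 3 is expected to give about 2200 nM in this assay, within a range from 700 nM to 7000 nM.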

Compound 3, half-maximal inhibitory concentration: 1680 nM
Compound 3: the middle estimate sits 1.3-fold (0.12 log units) above what was measured, within the range that was stated.
By their numbers in this assay, from the lowest: compounds 3, 1 and 2 (each within the scatter of the next, the first and the last beyond it).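

On the saturated chain carbon bound to a double-bonded chain carbon, piperidin-1-yl stands in place of ethyl with a 1.9-fold lower number from compound 1 to compound 3 (0.27 log units; within the scatter) in this assay, so this exchange of a plain chain end for a six-membered ring holding a nitrogen leaves the number within the scatter of compound 1. Within the data shown here, the earlier pair changed only the ether on the aromatic ring, so this is the first reading on the chain carrying the amide, and it remains a single one. Nothing at hand offers an explanation for the numbers of these compounds.

On these data alone, whether a dimethylamino group, a morpholin-4-yl ring or a carboxylic acid on the same carbon would also stay within the scatter of compound 1 remains open. As far as these compounds go, it is also open how the oxolan-3-yl ether and the piperidin-1-yl chain would read together on one molecule.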